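The source may report more compounds than this note shows. Statements on the series, on what has been measured and on what is new or still open speak of the compounds shown alone.

Three compounds share one core and differ only in the aromatic ring attached to it. In a functional assay on aorta (Rattus norvegicus) for inhibition (a lower number here means that less compound is needed, a higher number that more compound is needed for the effect), compound 1 `CCOC(=O)c1c(C)[nH]c(=O)c(C#N)c1-c1ccc([N+](=O)[O-])cc1` gives 8200 nM, the lowest of the three numbers. Among the measured compounds shown here, compound 3 `CCOC(=O)c1c(C)[nH]c(=O)c(C#N)c1-c1cccc(Cl)c1` gives 62000 nM, and compound 2 `CCOC(=O)c1c(C)[nH]c(=O)c(C#N)c1-c1ccncc1` gives 178000 nM; the single recorded step, a 2.9-fold lower number from compound 2 to compound 3 (0.46 log units; beyond the scatter), exchanges the whole ring. Compound 4 `CCOC(=O)c1c(C)[nH]c(=O)c(C#N)c1-c1ccc([N+](=O)[O-])cc1[N+](=O)[O-]` has not yet been measured in this assay. It differs from compound 1 by nitro in place of hydrogen on an aromatic carbon. For the measured compounds named here, no measured step adds a nitro group, so the only guide is that compound 1 stands alone at 8200 nM and that ring changes so far moved numbers modestly. A step of a 1.8-fold higher number from compound 1 to compound 4 (0.26 log units; within the scatter) is therefore expected. For compound 4 the estimate is 15000 nM, within 3000 nM to 60000 nM.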

Compound 4, half-maximal effective concentration: 3600 nM
Beside the measured number, compound 4's estimate is 4.2-fold (0.62 log units) above it; low and high end bracket the measured number.
By their numbers in this assay, from the lowest: compound 4; then compound 1; then compound 3; then compound 2.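

In this assay, placing a nitro group ortho to a large group and meta to the existing nitro group gives a 2.3-fold lower number from compound 1 to compound 4 (0.36 log units; beyond the scatter). Among the compounds shown here, this is the first step here that adds a group to the ring rather than exchanging the whole ring, and it shows that this position accepts a nitro group and lowers the number. Nothing available here gives a reason for the drop. On these data alone, whether an amine or a carboxylic acid at this position would also lower the number remains open. So does whether a nitro group here would lower it without the existing nitro group.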